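Moving the Fluorine on the Hydrazone Aryl of Compound 1

The source may report more compounds than this note shows. Statements on the series, on what has been measured and on what is new or still open speak of the compounds shown alone.

Measured so far:
Compound 1, `Cc1nc(N(C)C(=O)NC(=O)c2c(F)cccc2F)sc1C(=O)N/N=C/c1ccccc1F`, gives > 100 ug/mL in a functional assay on HepG2 cells (Homo sapiens) for inhibition, read by MTT assay, with a stated time of 72 h; on this read-out lower numbers stand for stronger inhibition and higher numbers for weaker inhibition.
Compound 2, `CN(C(=O)NC(=O)c1ccc(Cl)c(Cl)c1)c1nc(C(F)(F)F)c(C(=O)N/N=C/c2ccc([N+](=O)[O-])cc2)s1`, gives 6.85 ug/mL.
Compound 3, `CN(C(=O)NC(=O)c1ccc(C(F)(F)F)cc1)c1nc(C(F)(F)F)c(C(=O)N/N=C/c2ccc(C(F)(F)F)cc2)s1`, gives > 100 ug/mL.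

The value for compound 1 is a limit of the measurement, not a number. The value for compound 3 is also a limit. Compound 2 is the only one of the three with a number. Where compound 1 stands is told by the limit of > 100 ug/mL in this assay, at which 2 of the 3 values shown sit.

Compound 4, `Cc1nc(N(C)C(=O)NC(=O)c2c(F)cccc2F)sc1C(=O)N/N=C/c1ccc(F)cc1`, has the same atoms as compound 1, joined differently: 4-fluorophenyl in place of 2-fluorophenyl on a carbon with a double bond to nitrogen. Among the compounds with values here, no pair of measured compounds differs in one place only, so the size of a step of this kind is unknown here. Compound 4 is expected to sit near compound 1, with a number no higher from compound 1 to compound 4 (the limit leaves the size open) expected to be no larger than the scatter. The estimate for compound 4 is 100 ug/mL, within the range 30 ug/mL to 300 ug/mL.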

Compound 4, half-maximal inhibitory concentration: > 100 ug/mL
Compound 4: a limit, no number (the forecaster's own chance of this, stated with the estimate: 75%); the middle value sits exactly at the limit.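

Compound 1 and compound 4 both give a limit rather than a number, so the step between them cannot be read: the limit of > 100 ug/mL in this assay, at which 3 of the 4 values shown sit.

As far as these compounds go, whether 4-fluorophenyl in place of 2-fluorophenyl changes inhibition at all remains open.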